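Compound 3: from fluoro to methyl

A few compounds are considered here, and "the series" means these few. Any claim that something is new, unique, unknown or untested is made for them only; others in the source may bear on it.

Compound 1 `COc1ccc(/C=C2\CCC/C(=C\c3ccccc3[N+](=O)[O-])C2=O)cc1`: > 400000 nM (a limit of the assay)
Compound 2 `O=C1/C(=C/c2ccc(F)cc2)CCC/C1=C\c1cccc([N+](=O)[O-])c1`: 38000 nM

For the measured compounds named here, in an ADME assay on HPC cells (Homo sapiens) for cytotoxicity, with a stated time of 24 h (a higher number here means that more compound is tolerated, a lower number that less compound is tolerated), compound 2 gives 38000 nM, the only true number available. Compound 1 gives > 400000 nM, which is a limit and not a number. Compound 3 `Cc1ccc(/C=C2\CCC/C(=C\c3cccc([N+](=O)[O-])c3)C2=O)cc1` has methyl in place of fluoro on an aromatic carbon, para to a large group: methyl in place of fluoro on an aromatic carbon. Going by the values given here, no measured pair shows this change, so the expectation rests on compound 2 and its 38000 nM. The expected move is a 1.1-fold lower number from compound 2 to compound 3 (0.04 log units; within the scatter), with no step beyond the scatter in either direction. For compound 3 the estimated half-maximal cytotoxic concentration is 35000 nM, with an expected range of 12000 nM to 110000 nM.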

Compound 3, half-maximal cytotoxic concentration in the HPC assay: 192000 nM
For compound 3 the middle estimate is 5.5-fold (0.74 log units) below the measured one; the measured number lies above the stated range.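

In the HPC assay, compound 2 gives 38000 nM and compound 3 gives 192000 nM. In the HPC assay, methyl in place of fluoro gives a 5.1-fold higher number from compound 2 to compound 3 (0.70 log units; beyond the scatter), so this place, on an aromatic carbon and para to a large group, responds to the exchange of one heavy atom for another. In a physicochemical assay for lipophilicity (a higher number here means a more lipophilic compound, a lower number a more polar compound), compound 2 gives 5.07 and compound 3 gives 5.35. In the physicochemical assay, the same change gives a number 0.28 log units higher from compound 2 to compound 3 (within the scatter), so the step in tolerated concentration comes without a partition coefficient step beyond the scatter. On these data alone, whether chloro or an amine at this place would shift the tolerated concentration further stays open. Nothing shown bears on why the step occurs.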